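The source may report more compounds than this note shows. Statements on the series, on what has been measured and on what is new or still open speak of the compounds shown alone.

Measured so far:
Compound 1, `Nc1cc(-c2ccccc2)ccc1Cn1cncc1CNc1ccc(-c2cncs2)c(-c2ccccc2)c1`: in a toxicity assay on NIH3T3 cells (Mus musculus) for cytotoxicity, read by resazurin assay (a higher number here means that more compound is needed for the effect, a lower number that less compound is needed), compound 1 gives > 1000 nM, which is a limit of the assay and not a number.
Compound 2, `COC(=O)c1ccc(NCc2cncn2Cc2cccc(C#N)c2)cc1-c1ccccc1`: in this assay compound 2 gives > 10000 nM, again a limit.
Compound 3, `c1ccc(-c2ccc(Cn3cncc3CNc3ccccc3-c3ccccc3)cc2)cc1`: in this assay compound 3 gives > 10000 nM, again a limit.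

None of the three values is a number. Two sit at the limit of > 10000 nM in this assay, at which 2 of the 3 values shown sit, and one at the limit of > 1000 nM in this assay, at which 1 of the 3 values shown sits. Among the compounds with values here, compound 2 stands at the higher of the two limits; as the values are limits, no order among the three compounds can be read from them, and no pair differs in a single place, so no measured step exists in the set.

Compound 4, `COC(=O)c1ccc(NCc2cncn2Cc2ccccc2C#N)cc1-c1ccccc1`, differs from compound 2 by 2-cyanophenyl in place of 3-cyanophenyl on a saturated chain carbon bound to an aromatic nitrogen. Nothing in the set reports a number for this change or for any other. The expectation for the step that the limit leaves unreadable from compound 2 to compound 4 is therefore none beyond the usual scatter, resting on compound 2 at > 10000 nM. Compound 4 is expected to give about 15000 nM in this assay, within 5000 nM to 50000 nM, and most probably the assay will again report only a limit for compound 4.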

Compound 4, half-maximal effective concentration: 25000 nM
Beside the measured number, compound 4's estimate is 1.7-fold (0.22 log units) below it; the measured number falls inside the stated range.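

In this assay compound 2 gives > 10000 nM, a limit and not a number, and the step to compound 4 therefore cannot be read. The compounds shown leave open whether 2-cyanophenyl in place of 3-cyanophenyl on this saturated chain carbon changes the value in this assay at all.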